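Exchanging the Bicyclic Amide Substituent on a Shared Core

A few compounds are considered here, and "the series" means these few. Any claim that something is new, unique, unknown or untested is made for them only; others in the source may bear on it.

Compound 1 `CCOc1ncc(-c2nc(C(F)(F)F)sc2N2CCN(C(=O)Cn3ccc4cnccc43)[C@H](C)C2)cn1` and compound 2 `CCOc1ncc(-c2nc(C(F)(F)F)sc2N2CCN(C(=O)Cn3ncc4cccnc43)[C@H](C)C2)cn1` share one core and differ only in the bicyclic group carried on a saturated chain carbon bound to a carbonyl carbon. In a functional assay on CHO-K1 cells for antagonist activity at C-X-C chemokine receptor type 3 (Homo sapiens), read by FLIPR, with a stated time of 10 min (on this read-out higher numbers stand for weaker inhibition and lower numbers for stronger inhibition), compound 1 gives 3.6 nM. In this assay compound 2 gives 4.1 nM, the higher of the two numbers shown, though it sits within the scatter of compound 1. The step of a 1.1-fold higher number from compound 1 to compound 2 (0.06 log units; within the scatter) shows that replacing one bicyclic group by another at this place left the read-out essentially where it was.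

Compound 3 `CCOc1ncc(-c2nc(C(F)(F)F)sc2N2CCN(C(=O)Cn3c(=O)oc4ccccc43)[C@H](C)C2)cn1` has not yet been measured. It differs from compound 2 by a group of 10 heavy atoms (7 carbon, 1 nitrogen, 2 oxygen; one five-membered aromatic ring with 2 hetero atoms, one six-membered aromatic ring of carbon only) in place of a group of 9 heavy atoms (6 carbon, 3 nitrogen; one five-membered aromatic ring with 2 hetero atoms, one six-membered aromatic ring with 1 hetero atom), on a saturated chain carbon bound to a carbonyl carbon. For the measured compounds named here, the only measured step that bears on this change is a 1.1-fold higher number from compound 1 to compound 2 (0.06 log units; within the scatter), an exchange of the same kind at the same place that stayed within the scatter. On that single precedent no step beyond the scatter is expected in this assay, in either direction, but one prior step is thin ground and the range is kept wide. Compound 3 is therefore estimated at 6 nM, with 2 nM to 20 nM as its range. The expected step is a 1.5-fold higher number from compound 2 to compound 3 (0.17 log units; within the scatter).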

Compound 3, half-maximal inhibitory concentration: 3.3 nM
The estimate for compound 3 lay 1.8-fold (0.26 log units) above the measured number, and the stated range covers the measured number.
By their numbers in this assay, from the lowest: compounds 3, 1 and 2 (each within the scatter of the next).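

With compound 3, the position on a saturated chain carbon bound to a carbonyl carbon now has a third bicyclic group, one with a six-membered aromatic ring of carbon only and 1 double bond outside aromatic rings, and in this assay the read-out gives a 1.2-fold lower number from compound 2 to compound 3 (0.09 log units; within the scatter) and a 1.1-fold lower number from compound 1 to compound 3 (0.04 log units; within the scatter). Compounds 1 and 2 had shown only exchanges among groups whose six-membered aromatic ring carries 1 hetero atom, whereas these steps show that, among the three compounds, a six-membered aromatic ring of carbon only and added oxygen atoms in the entering group still leave all three numbers within the scatter of one another. The data shown offer no independent measurement that could account for this similarity.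

Going by these compounds, all three compounds carry a bicyclic group at this place, so it remains open how a single phenyl ring, a primary amine or a carboxylic acid on the same carbon would read in this assay. Also open, on these data alone, is whether the agreement among compounds 1, 2 and 3 would hold in any other read-out.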